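Swapping Amino for Chloro on an Azido Nucleoside Core

The source may hold more compounds than are shown below. What is called first, only, known or untested is meant among the compounds shown, and "the series" means these compounds.

Compound 1, `CNc1nc(Cl)nc2c1ncn2[C@H]1C[C@H](N=[N+]=[N-])[C@@H](CO)O1`: in an ADME assay on Vero cells (Chlorocebus sabaeus) for cytotoxicity, with a stated time of 5 days (on this read-out lower numbers stand for stronger inhibition and higher numbers for weaker inhibition), compound 1 gives > 100000 nM, a limit of the assay rather than a number.
Compound 2, `[N-]=[N+]=N[C@H]1C[C@H](n2cnc3c(NC4CC4)nc(N)nc32)O[C@@H]1CO`: in this assay compound 2 gives > 100000 nM, again a limit and not a number.

Among the compounds with values here, compound 2 therefore stands at the edge of what this assay can report, and it is not alone there: the only evidence in hand is the limit of > 100000 nM in this assay, at which 2 of the 2 values shown sit. Within the data shown here, no pair of measured compounds differs in just one place, so no measured step exists to lean on.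

Compound 3, `[N-]=[N+]=N[C@H]1C[C@H](n2cnc3c(NC4CC4)nc(Cl)nc32)O[C@@H]1CO`, differs from compound 2 by chloro in place of amino on an aromatic carbon. With both measured compounds sitting at the same limit, the change is expected to move nothing beyond the usual scatter, so the step that the limit leaves unreadable from compound 2 to compound 3 is expected to be essentially flat, because the two shared values both fall at the limit of > 100000 nM in this assay, at which 2 of the 2 values shown sit. Compound 3 is expected to give about 150000 nM in this assay, with a likely range from 50000 nM to 500000 nM, and most probably the assay will again report only a limit.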

Compound 3, half-maximal inhibitory concentration: > 100000 nM
Compound 3: a limit, no number (the forecaster's own chance of this, stated with the estimate: 80%); the middle value lies beyond the limit too.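

In this assay compound 3 gives > 100000 nM, a limit and not a number. The steps linking compound 3 to compound 1 and to compound 2 therefore cannot be read: the limit of > 100000 nM in this assay, at which 3 of the 3 values shown sit.

The compounds shown leave open whether chloro in place of amino, or cyclopropyl in place of methyl, changes anything in this assay.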